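This account rests on a few compounds, and the source may have more. Where it says the series, first, only, none or still open, it means among the compounds named here.

Series notes. Compound 2 `CC1=C(C(C)C(=O)NCCN2CCCC2)c2cc(F)ccc2/C1=C\c1ccc([S+](C)[O-])cc1` in a functional assay on HT-29 cells (Homo sapiens) for inhibition, read by CellTiter-Glo, with a stated time of 72 h (a lower number here means that less compound is tolerated, a higher number that more compound is tolerated), gives 13700 nM, the second highest of the three numbers measured. Compound 1 `CC1=C(C(C)C(=O)N(CCNC(C)C)C(C)C)c2cc(F)ccc2/C1=C\c1ccc([S+](C)[O-])cc1` gives 8060 nM in this assay, and the step of a 1.7-fold higher number from compound 1 to compound 2 (0.23 log units; within the scatter) is within the scatter. Compound 3 `CC1=C(C(C)C(=O)N2CCN(CCCN(C)C)CC2)c2cc(F)ccc2/C1=C\c1ccc([S+](C)[O-])cc1` gives 32000 nM in this assay; the step of a 2.3-fold higher number from compound 2 to compound 3 (0.37 log units; beyond the scatter) is beyond the scatter, as is a 4.0-fold higher number from compound 1 to compound 3 (0.60 log units; beyond the scatter). Compound 4 `CC1=C(C(C)C(=O)N2CCN(c3ccncc3)CC2)c2cc(F)ccc2/C1=C\c1ccc([S+](C)[O-])cc1` has not yet been measured in this assay. The change is 4-(pyridin-4-yl)piperazin-1-yl in place of (2-(pyrrolidin-1-yl)ethyl)amino on a carbonyl carbon. The measured step that bears on it is the one that also replaced the (2-(pyrrolidin-1-yl)ethyl)amino group with a substituted piperazin-1-yl ring on the carbonyl carbon and gave a 2.3-fold higher number from compound 2 to compound 3 (0.37 log units; beyond the scatter); the step of a 4.0-fold higher number from compound 1 to compound 3 (0.60 log units; beyond the scatter) points the same way. For the measured compounds named here, the entering group here carries a pyridin-4-yl on the piperazin-1-yl ring instead of a 3-(dimethylamino)propyl chain, and no measured compound covers that substituent, so the size of the step is uncertain. For compound 4 a modest rise in the number is therefore expected, a 1.8-fold higher number from compound 2 to compound 4 (0.26 log units; within the scatter), of roughly the size of that earlier step. The estimate for compound 4 in this assay is 25000 nM, with a range from 10000 nM to 60000 nM.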

Compound 4, half-maximal cytotoxic concentration: 4990 nM
Estimate against measurement, compound 4: 5.0-fold (0.70 log units) above; measured number outside the range, below it.
By their numbers in this assay, from the lowest: compounds 4, 1 and 2 (each within the scatter of the next, the first and the last beyond it); then compound 3.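

In this assay a substituted piperazin-1-yl ring on the carbonyl carbon does not by itself set the direction of the number: one such replacement gives a 2.3-fold higher number from compound 2 to compound 3 (0.37 log units; beyond the scatter) and the other gives a 2.7-fold lower number from compound 2 to compound 4 (0.44 log units; beyond the scatter), so the earlier rise cannot be credited to the ring alone. For the compounds shown here, the group on the amine nitrogen in the ring matters at this position, since pyridin-4-yl in place of 3-(dimethylamino)propyl gives a 6.4-fold lower number from compound 3 to compound 4 (0.81 log units; beyond the scatter) and this is the one comparison here with the piperazin-1-yl ring held constant, while a 1.6-fold lower number from compound 1 to compound 4 (0.21 log units; within the scatter) leaves compound 1 and compound 4 not separated in this read-out. No measurement at hand explains these differences.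

From the compounds shown here alone, it remains open whether the lower number of compound 4 goes with an aromatic ring on the piperazin-1-yl ring as such or with the place of its ring nitrogen, a question that a phenyl or a pyridin-3-yl group on the same ring nitrogen would address. Also open, going by these compounds, is how the number moves with chain length, as a 2-(dimethylamino)ethyl or a longer 4-(dimethylamino)butyl chain in place of 3-(dimethylamino)propyl would show.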